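Para-substituent swap on the benzohydrazide of a diiodosalicylaldehyde series

This account rests on a few compounds, and the source may have more. Where it says the series, first, only, none or still open, it means among the compounds named here.

Measured so far:
compound 1 `O=C(N/N=C/c1cc(I)cc(I)c1O)c1ccc(F)cc1` — 12100 nM
compound 2 `O=C(N/N=C/c1cc(I)cc(I)c1O)c1ccc(Br)cc1` — 22300 nM

In a functional assay on HepG2 cells (Homo sapiens) for cytotoxicity, with a stated time of 24 h (on this read-out higher numbers stand for weaker inhibition and lower numbers for stronger inhibition), compound 1 gives 12100 nM and compound 2 gives 22300 nM. Compound 2 holds the highest of the two numbers, and its nearest neighbour is compound 1; the step of a 1.8-fold higher number from compound 1 to compound 2 (0.27 log units; within the scatter) is within the scatter. Compound 3 `O=C(N/N=C/c1cc(I)cc(I)c1O)c1ccc(C(F)(F)F)cc1` differs from compound 2 by trifluoromethyl in place of bromo on an aromatic carbon. Among the measured compounds shown here, the only step that bears on this, a 1.8-fold higher number from compound 1 to compound 2 (0.27 log units; within the scatter), shows that swapping one halogen for another on this aromatic carbon changed nothing beyond the scatter, so for the trifluoromethyl group no step beyond the scatter is expected in this assay either. Compound 3 is therefore estimated at 20000 nM (range 8000 nM to 50000 nM), a step of a 1.1-fold lower number from compound 2 to compound 3 (0.05 log units; within the scatter) that is expected to stay within the scatter.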

Compound 3, half-maximal inhibitory concentration: 11700 nM
Compound 3: the middle estimate sits 1.7-fold (0.23 log units) above what was measured; the range from low to high includes it.
By their numbers in this assay, from the lowest: compounds 3, 1 and 2 (each within the scatter of the next).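

Trifluoromethyl in place of bromo gives a 1.9-fold lower number from compound 2 to compound 3 (0.28 log units; within the scatter) in this assay and trifluoromethyl in place of fluoro gives a 1.0-fold lower number from compound 1 to compound 3 (0.01 log units; within the scatter) on the same read-out, so a group other than a halogen on this aromatic carbon also stays within the scatter. No order can be drawn among the three groups at this place. Nothing on hand offers an explanation for this result.

On these data alone, whether an amine, a carboxylic acid or a longer chain on this carbon would move the number beyond the scatter remains open.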